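The source may hold more compounds than are shown below. What is called first, only, known or untested is meant among the compounds shown, and "the series" means these compounds.

Compound 1 `Cc1cc(NC(=O)Nc2ccc(N)cc2)c2ccccc2n1` — in an ADME assay on Raji cells (Homo sapiens) for cytotoxicity, with a stated time of 72 h (a lower number here means that less compound is needed, a higher number that more compound is needed for the effect), compound 1 gives > 25000 nM, which is a limit of the assay and not a number.
Compound 2 `Cc1cc(NC(=O)Nc2ccccc2N)c2ccccc2n1` — compound 2 gives > 25000 nM, likewise a limit.
Compound 3 `Cc1cc(NC(=O)Nc2cccnc2)c2ccccc2n1` — compound 3 gives > 25000 nM, again a limit.

All three values sit at the limit of > 25000 nM in this assay, at which 3 of the 3 values shown sit, so compound 1 stands at the limit rather than at any measured number. The steps a step that the two limits leave unreadable from compound 1 to compound 2, a step that the two limits leave unreadable from compound 1 to compound 3 and a step that the two limits leave unreadable from compound 2 to compound 3 therefore cannot be read for size. Compound 4 `Cc1cc(NC(=O)Nc2ccc(OC(F)(F)F)cc2)c2ccccc2n1` differs from compound 1 by trifluoromethoxy in place of amino on an aromatic carbon. Going by the values given here, no measured step involves this change, and none has a readable size, so no direction beyond the scatter can be expected. Compound 4 is estimated at 20000 nM (range 5000 nM to 60000 nM), an expected step of an at least 1.2-fold lower number from compound 1 to compound 4 (0.09 log units; that floor lies within the scatter), with a good chance that only a limit is reported again.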

Compound 4, half-maximal effective concentration: 10000 nM
Estimate against measurement, compound 4: 2.0-fold (0.30 log units) above; the measured number falls inside the stated range.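

In this assay, going by these compounds alone, trifluoromethoxy in place of amino on this aromatic carbon gives the first step that can be read, an at least 2.5-fold lower number from compound 1 to compound 4 (0.39 log units; beyond the scatter). The steps among compound 1, compound 2 and compound 3 cannot be read, and this new step gives only a floor, with the true size possibly larger. Compound 4 is the only compound here with a measured number rather than a limit: the limit of > 25000 nM in this assay, at which 3 of the 4 values shown sit.

On these data alone, whether the lower number is specific to trifluoromethoxy remains open. As far as these compounds go, how a methoxy, a chlorine or a trifluoromethyl at this position would compare also remains unknown.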